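This account rests on a few compounds, and the source may have more. Where it says the series, first, only, none or still open, it means among the compounds named here.

Working notes on the series. For the measured compounds named here, all three compounds measured so far share the propanoic acid chain and the phenoxymethyl link to a five-membered heteroaromatic ring. In a functional assay on CHO cells for agonist activity at Free fatty acid receptor 1 (Homo sapiens), read by FLIPR and calcium flux, in the presence of a further agent that is not named here (a lower number here means that less compound is needed, a higher number that more compound is needed for the effect), compound 1 `O=C(O)CCc1ccc(OCc2coc(-c3cccc(Cl)c3)n2)cc1` gives 160 nM. Compound 2 `O=C(O)CCc1ccc(OCc2noc(-c3ccccc3)n2)cc1` gives 2650 nM in this assay. Compound 3 `O=C(O)CCc1ccc(OCc2nc(-c3cccc(Br)c3)no2)cc1` gives 1260 nM in this assay, which places it second highest of the three numbers; its nearest neighbour is compound 2, the gap to which lies beyond the scatter, and its furthest is compound 1, with a gap well beyond the scatter.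

Compound 4 `O=C(O)CCc1ccc(OCc2nc(-c3ccc(F)cc3)no2)cc1` has not been measured. It differs from compound 3 in one place: 4-fluorophenyl in place of 3-bromophenyl on an aromatic carbon. Going by the values given here, no measured pair shows this change directly, so the expected step is judged from the neighbours only. Compound 2, which carries an unsubstituted phenyl on a related core, gives 2650 nM, a higher number than compound 3. For compound 4 a modestly higher number than compound 3 is expected, a small step of a 1.6-fold higher number from compound 3 to compound 4 (0.20 log units; within the scatter) in this assay, perhaps not clearly beyond the scatter. Compound 4 is estimated at 2000 nM, within a range of 800 nM to 5000 nM.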

Compound 4, half-maximal effective concentration: 680 nM
For compound 4 the middle estimate is 2.9-fold (0.47 log units) above the measured one, outside the stated range (below it).
By their numbers in this assay, from the lowest: compound 1; then compounds 4 and 3 (each within the scatter of the next); then compound 2.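

In this assay, for the compounds shown here, the first direct pair on the shared core, 4-fluorophenyl in place of 3-bromophenyl on this aromatic carbon, gives a step that stays within the scatter (a 1.9-fold lower number from compound 3 to compound 4 (0.27 log units; within the scatter)). At this position, two ring bonds from the ring oxygen, the two halogen-bearing phenyl groups are therefore not told apart by this read-out. Nothing available bears on the reason for this result.

As far as these compounds go, the step exchanges the halogen and its place on the phenyl ring at once, so it remains open whether 3-fluorophenyl or 4-bromophenyl on this core would separate the two. From the compounds shown here alone, it is also open how an unsubstituted phenyl, or a phenyl carrying a methoxy group or an amine, would read on this core.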